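A few compounds are considered here, and "the series" means these few. Any claim that something is new, unique, unknown or untested is made for them only; others in the source may bear on it.

Measured in a functional assay on OVCAR-3 cells (Homo sapiens) for antiproliferative activity, read by MTT assay, with a stated time of 24 h; a higher number here means a weaker inhibitor, a lower number a stronger inhibitor:

Compound 1 `Cc1ccccc1NNC(=O)c1ccccc1NS(=O)(=O)c1cnc(O)nc1O`: > 20000 nM, a limit of the assay
Compound 2 `Cc1cccc(NNC(=O)c2ccccc2NS(=O)(=O)c2cnc(O)nc2O)c1`: > 20000 nM, a limit of the assay
Compound 3 `CCCCOc1ccc(C(=O)NNC(=O)c2ccccc2NS(=O)(=O)c2cnc(O)nc2O)cc1`: 5010 nM

Among the measured compounds shown here, compound 3 gives the only actual number in this small set, at 5010 nM. The other two results are limits, so they do not allow an exact ranking against it.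

The next compound is compound 4 `O=C(NNC(=O)c1ccccc1NS(=O)(=O)c1cnc(O)nc1O)c1ccccc1Cl`. The change is 2-chlorophenyl in place of 4-butoxyphenyl on a carbonyl carbon.

For the measured compounds named here, no measured step covers this change. Going by the values given here, the only one available is a step that the two limits leave unreadable from compound 1 to compound 2, which involves 3-methylphenyl in place of 2-methylphenyl on an amine nitrogen, and it provides no size to carry over. The expectation therefore rests on two reference points. One is compound 3 at 5010 nM. The other is the limit of > 20000 nM in this assay, at which 2 of the 3 values shown sit.

With so little to go on, a move toward weaker inhibition in this assay is expected, though this is a judgement rather than a measured trend. The expected step is a 2.8-fold higher number from compound 3 to compound 4 (0.45 log units; beyond the scatter), and this estimate is very uncertain. For compound 4 the estimated value is 14000 nM, with an expected range from 5000 nM to 40000 nM.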

Compound 4, half-maximal inhibitory concentration: 18200 nM
Beside the measured number, compound 4's estimate is 1.3-fold (0.11 log units) below it; low and high end bracket the measured number.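

In this assay, among the compounds shown here, the change on a carbonyl carbon from 4-butoxyphenyl to 2-chlorophenyl gives a 3.6-fold higher number from compound 3 to compound 4 (0.56 log units; beyond the scatter), the first step in this set whose size can be read, and it shows that the group at this place affects the read-out. The 2-chlorophenyl group has fewer heavy atoms than 4-butoxyphenyl and lacks its hydrogen-bond acceptor, but these differences arrive together, so this single step cannot assign the shift to any one of them. The comparisons with the two compounds held at a limit of the assay, an at least 1.0-fold lower number from compound 2 to compound 4 (0.04 log units; that floor lies within the scatter) and an at least 1.0-fold lower number from compound 1 to compound 4 (0.04 log units; that floor lies within the scatter), give only floors and so establish no real difference, and the measured value of compound 4 lies close to that limit: the limit of > 20000 nM in this assay, at which 2 of the 4 values shown sit.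

As far as these compounds go, it remains open whether the stronger result of compound 3 depends on the butoxy chain itself or on a substituent at that ring position in general. A 4-chlorophenyl or 4-methoxyphenyl group on the same carbonyl carbon would help separate these two readings, and a longer alkoxy chain would show whether the trend extends further.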